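Hydroxycarbamoyl chain change from compound 1 to compound 3

The source may report more compounds than this note shows. Statements on the series, on what has been measured and on what is new or still open speak of the compounds shown alone.

Among the measured compounds shown here, in a functional assay on ES2 cells (Homo sapiens) for inhibition, read by MTT assay, with a stated time of 48 h (on this read-out lower numbers stand for stronger inhibition and higher numbers for weaker inhibition), compound 1 (`O=C(CCCCOc1no[n+]([O-])c1S(=O)(=O)c1ccccc1)NO`) gives 2530 nM and holds the lower of the two numbers so far. Compound 2 (`CC(C)(COc1no[n+]([O-])c1S(=O)(=O)c1ccccc1)C(=O)NO`) gives 6880 nM in this assay and is the nearest neighbour. Compound 3 (`O=C(NO)OCCOCCOc1no[n+]([O-])c1S(=O)(=O)c1ccccc1`) is still unmeasured. It carries 2-((hydroxycarbamoyl)oxy)ethoxy in place of 2-(hydroxycarbamoyl)ethyl on a saturated chain carbon, two bonds along the chain from an oxygen on an aromatic ring. For the measured compounds named here, only one measured step bears on this chain: a 2.7-fold higher number from compound 1 to compound 2 (0.43 log units; beyond the scatter) is modest and beyond the scatter, but it is a different change, so it is a weak guide. Going by the values given here, no measured compound carries the new chain. A small move towards a higher number is expected, with a 1.6-fold higher number from compound 1 to compound 3 (0.20 log units; within the scatter) as the estimated step. For compound 3 the estimate is 4000 nM within an expected range of 1400 nM to 11000 nM in this assay for now.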

Compound 3, half-maximal inhibitory concentration: 18100 nM
The estimate for compound 3 lay 4.5-fold (0.66 log units) below the measured number; the measured number lies above the stated range.
By their numbers in this assay, from the lowest: compound 1; then compound 2; then compound 3.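

In this assay, the move to 2-((hydroxycarbamoyl)oxy)ethoxy gives a 7.2-fold higher number from compound 1 to compound 3 (0.85 log units; beyond the scatter), so this saturated chain position does respond to a change that keeps the chain unbranched and adds oxygens, with 4 oxygens entering where 2 leave. Together with a 2.7-fold higher number from compound 1 to compound 2 (0.43 log units; beyond the scatter), this leaves both replacements of the chain of compound 1 on the higher-number side, and compound 1 remains the lowest of the series. Nothing available accounts for the size of the new step.

Among the compounds shown here, the single step changes both the oxygen content of the chain and the link to the hydroxycarbamoyl end, and the two cannot be separated here. As far as these compounds go, whether a longer all-carbon chain, or a carboxylic acid at the chain end, would hold the number of compound 1 remains open.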